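The source may report more compounds than this note shows. Statements on the series, on what has been measured and on what is new or still open speak of the compounds shown alone.

Measured compounds:
compound 1 `N=C(N)c1ccc(-c2ccc(-c3ccc(F)cc3)o2)o1` — "not determined" (no result reported)
compound 2 `N=C(N)c1ccc(-c2ccc(-c3ccc4ccccc4c3)s2)s1` — 1950 nM

Working notes on the series. In a functional assay on T47D cells (Homo sapiens) for inhibition, read by sulforhodamine B assay, with a stated time of 48 h (on this read-out lower numbers stand for stronger inhibition of growth and higher numbers for weaker inhibition of growth), compound 1 has no reported result. In this assay compound 2 gives 1950 nM, and this single value is the only anchor for the series on this read-out. Among the measured compounds shown here, compound 1 therefore stands nowhere on the numbers: a starting point without a value of its own, and no step from it to another measured compound can be given.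

Compound 3 `COc1ccc(-c2ccc(-c3ccc(C(=N)N)o3)o2)cc1` is the next compound to be measured. It differs from compound 1 in one place: methoxy in place of fluoro on an aromatic carbon. For the measured compounds named here, with no measured pair showing a step of this kind, and no number for compound 1, the size of the step in this assay cannot be read off; the working expectation is a step no larger than the usual scatter, in either direction.

Compound 3 is expected to give 3000 nM in this assay, with a range from 800 nM to 12000 nM, an estimate resting on the value of compound 2 1950 nM as the sole measured point.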

Compound 3, concentration for 50% growth inhibition: 1530 nM
Estimate against measurement, compound 3: 2.0-fold (0.29 log units) above; the range from low to high includes it.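

In this assay, among the compounds shown here, compound 1 has no number, and no step from it to compound 3 can be read. The compounds shown leave open how far methoxy in place of fluoro shifts the result in this assay. No supporting measurement is available to bear on the value of compound 3.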